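From Nitro to Thiophene in a Cyclic Urea Series

The source may hold more compounds than are shown below. What is called first, only, known or untested is meant among the compounds shown, and "the series" means these compounds.

In an assay on RBL-1 cells for inhibition of Polyunsaturated fatty acid 5-lipoxygenase (Rattus norvegicus) (a lower number here means a stronger inhibitor, a higher number a weaker inhibitor), three compounds have been measured:
Compound 1 `O=C1NCCN(c2cccc(Cl)c2)N1`: 5300 nM
Compound 2 `COc1cccc(N2CCNC(=O)N2)c1`: 47000 nM
Compound 3 `O=C1NCCN(c2cccc([N+](=O)[O-])c2)N1`: 49000 nM

Compound 3 gives the highest number of the three; compound 2 sits within the scatter of it, as a 1.0-fold higher number from compound 2 to compound 3 (0.02 log units; within the scatter) shows, while compound 1 lies well below it, as a 9.2-fold higher number from compound 1 to compound 3 (0.97 log units; beyond the scatter) shows. Compound 4 `O=C1NCCN(c2cccc(-c3ccsc3)c2)N1` differs from compound 3 by thiophen-3-yl in place of nitro on an aromatic carbon. Among the compounds with values here, no measured step swaps a substituent for an aromatic ring; an 8.9-fold higher number from compound 1 to compound 2 (0.95 log units; beyond the scatter) and a 9.2-fold higher number from compound 1 to compound 3 (0.97 log units; beyond the scatter) show only that chloro outperforms methoxy and nitro on that aromatic carbon, and a 1.0-fold higher number from compound 2 to compound 3 (0.02 log units; within the scatter) that methoxy and nitro are alike. Without a direct precedent, a modest drop in number is expected for compound 4, a 6.1-fold lower number from compound 3 to compound 4 (0.79 log units; beyond the scatter). Compound 4 is therefore estimated at 8000 nM in this assay, with a range from 1500 nM to 40000 nM.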

Compound 4, half-maximal inhibitory concentration: 4900 nM
Compound 4: the middle estimate sits 1.6-fold (0.21 log units) above what was measured; low and high end bracket the measured number.
By their numbers in this assay, from the lowest: compounds 4 and 1 (each within the scatter of the next); then compounds 2 and 3 (each within the scatter of the next).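

In this assay, within the data shown here, thiophen-3-yl brings an aromatic ring onto this aromatic carbon for the first time, and the ring separates clearly from the two weaker substituents, with a 10-fold lower number from compound 3 to compound 4 (1.00 log units; beyond the scatter) and a 9.6-fold lower number from compound 2 to compound 4 (0.98 log units; beyond the scatter). Against chloro no difference appears, with a 1.1-fold lower number from compound 1 to compound 4 (0.03 log units; within the scatter), so this position accepts an aromatic ring and a chloro alike. Nothing in the data at hand explains these steps. On these data alone, whether a phenyl or pyridine ring, an amine or a carboxylic acid on this carbon would keep pace with compound 1 and compound 4 remains open. So does the effect of thiophen-2-yl in place of thiophen-3-yl.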